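Swapping a nitro-bearing ring for a methyl-bearing ring

The source may report more compounds than this note shows. Statements on the series, on what has been measured and on what is new or still open speak of the compounds shown alone.

Compound 1 `Cc1cc(C)c(Oc2cc(Nc3ccc(C#N)cc3)ncc2C(=O)NCc2cn(CCCO)nn2)c(C)c1` gives 25200 nM in an ADME assay on MT4 cells (Homo sapiens) for cytotoxicity, read by MTT assay, with a stated time of 5 days; a higher number here means that more compound is tolerated, a lower number that less compound is tolerated.
Compound 2 `Cc1cc(C)c(Oc2cc(Nc3ccc(C#N)cc3)ncc2C(=O)NCc2cn(Cc3cccc([N+](=O)[O-])c3)nn2)c(C)c1` gives >= 156000 nM in this assay, a limit of the assay rather than a number.

Compound 2 thus sits at the ceiling of what was tested, as recorded in the limit of >= 156000 nM in this assay, at which 1 of the 2 values shown sits. Compound 3 `Cc1cc(C)c(Oc2cc(Nc3ccc(C#N)cc3)ncc2C(=O)NCc2cn(Cc3ccccc3C)nn2)c(C)c1` differs from compound 2 by 2-methylphenyl in place of 3-nitrophenyl on a saturated chain carbon bound to an aromatic nitrogen. Going by the values given here, the one measured step, an at least 6.1-fold higher number from compound 1 to compound 2 (0.79 log units; beyond the scatter), shows that replacing the 2-hydroxyethyl chain with an aromatic ring raised the tolerated concentration. Compound 3 keeps an aromatic ring at that position, so the step of an at least 1.3-fold lower number from compound 2 to compound 3 (0.11 log units; that floor lies within the scatter) is expected to be none beyond the scatter, with a fair chance of another limit. Compound 3 is therefore estimated at 120000 nM, with a range from 40000 nM to 200000 nM.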

Compound 3, half-maximal cytotoxic concentration: >= 164000 nM
Compound 3: only a limit was reported (the forecaster's own chance of this, stated with the estimate: 55%); at least 1.3-fold (0.13 log units) between middle value and limit.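

In this assay compound 3 also stops at a limit of the assay rather than a number: the limit of >= 164000 nM in this assay, at which 1 of the 3 values shown sits. Replacing the 2-hydroxyethyl group with 2-methylphenyl gives an at least 6.5-fold higher number from compound 1 to compound 3 (0.81 log units; beyond the scatter), so the gain first seen with 3-nitrophenyl also appears with a ring that carries methyl and no nitro group. Both benzyl compounds are limits, so the step between compound 2 and compound 3 cannot be read.

On these data alone, the true tolerated concentrations of these two compounds remain open. So does whether a benzyl ring bearing an amine or a carboxylic acid would follow the same pattern.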